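The compounds below may be only part of what the source reports. "The series", "measured", "known", "first", "only" and "open" are said of these compounds alone.

Two members of the series have been run in an assay on isolated protein for inhibition of thyroid hormone receptor beta (Homo sapiens), read by fluorescence polarization (on this read-out higher numbers stand for weaker inhibition and lower numbers for stronger inhibition), and neither gives a number. Compound 1 `CS(=O)(=O)c1ccc(C(=O)N2CCC(C(=O)N3CCN(c4ccc(F)cc4)CC3)CC2)cc1[N+](=O)[O-]` reaches only the assay limit, > 60000 nM. Compound 2 `CN(Cc1cccc(F)c1)C(=O)CCCNC(=O)c1ccc(S(C)(=O)=O)c([N+](=O)[O-])c1` likewise stops at the limit, > 60000 nM. Among the compounds with values here, both values thus sit at the same ceiling (the limit of > 60000 nM in this assay, at which 2 of the 2 values shown sit), so there is no measured step within the set to lean on. Compound 3 `CN(Cc1ccccc1F)C(=O)CCCNC(=O)c1ccc(S(C)(=O)=O)c([N+](=O)[O-])c1` differs from compound 2 by a single change: 2-fluorophenyl in place of 3-fluorophenyl on a saturated chain carbon bound to an amide-type nitrogen. No shift beyond the usual scatter is expected in this assay, so the step that the limit leaves unreadable from compound 2 to compound 3 is estimated as essentially flat. Compound 3 is expected to give about 80000 nM, within 30000 nM to 200000 nM, most likely again reported only as a limit.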

Compound 3, half-maximal inhibitory concentration: > 60000 nM
Compound 3: a limit, no number (the forecaster's own chance of this, stated with the estimate: 85%); the middle value does not contradict the limit.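

Compound 2 and compound 3 both stop at a limit in this assay, so no step can be read between them: the limit of > 60000 nM in this assay, at which 3 of the 3 values shown sit. Still open, on these data alone, is how 2-fluorophenyl and 3-fluorophenyl compare, and which change would give a measurable value.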